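The source may report more compounds than this note shows. Statements on the series, on what has been measured and on what is new or still open speak of the compounds shown alone.

In a functional assay on A549 cells (Homo sapiens), read by MTT assay, with a stated time of 72 h (a higher number here means a weaker inhibitor, a lower number a stronger inhibitor), the three measured compounds stand as follows.

Compound 1, `O=c1[nH]cnc2c1c(-c1ccsc1)cn2[C@@H]1O[C@H](CO)[C@@H](O)[C@H]1O`: > 20000 nM, a limit of the assay.
Compound 2, `O=c1[nH]cnc2c1c(-c1cc3ccccc3o1)cn2[C@@H]1O[C@H](CO)[C@@H](O)[C@H]1O`: > 20000 nM, a limit of the assay.
Compound 3, `O=c1[nH]cnc2c1c(-c1ccccc1)cn2[C@@H]1O[C@H](CO)[C@@H](O)[C@H]1O`: > 100000 nM, a limit of the assay.

Compound 1 therefore stands at a limit rather than at a number, as do the two other compounds; two of the three values sit at the limit of > 20000 nM in this assay, at which 2 of the 3 values shown sit, and the third at the limit of > 100000 nM in this assay, at which 1 of the 3 values shown sits. The steps among them, a step that the two limits leave unreadable from compound 1 to compound 2, a step that the two limits leave unreadable from compound 1 to compound 3 and a step that the two limits leave unreadable from compound 2 to compound 3, are each left unreadable by the limits at either end, so nothing about their size or direction can be drawn from them.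

Compound 4, `Nc1nc2c(c(-c3ccsc3)cn2[C@@H]2O[C@H](CO)[C@@H](O)[C@H]2O)c(=O)[nH]1`, differs from compound 1 by amino in place of hydrogen on an aromatic carbon. Within the data shown here, none of the measured steps touches this part of the shared core, so no measured step bears directly on it, and the three limits give no scale for any change. With compound 1 at > 20000 nM, compound 4 is expected to remain near a limit, and the step that the limit leaves unreadable from compound 1 to compound 4 is estimated to stay within the scatter. The estimate for compound 4 in this assay is 30000 nM, with a range from 5000 nM to 120000 nM.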

Compound 4, half-maximal inhibitory concentration: > 20000 nM
Compound 4 ended at the assay's limit; the forecaster's own chance of this, stated with the estimate: 70%; the middle value lies beyond the limit too.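

In this assay compound 4 gives > 20000 nM, a limit of the assay, and it shares that limit with other values: the limit of > 20000 nM in this assay, at which 3 of the 4 values shown sit. Compound 1 also stands at a limit, so the step between compound 1 and compound 4 cannot be read. The compounds shown leave open whether amino in place of hydrogen changes inhibition in either direction.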